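This account rests on a few compounds, and the source may have more. Where it says the series, first, only, none or still open, it means among the compounds named here.

Measured so far in a functional assay on SW-620 cells (Homo sapiens) for inhibition, read by MTT assay, with a stated time of 48 h; a lower number here means a stronger inhibitor, a higher number a weaker inhibitor:

- compound 1, `Cc1ccc(NC(=O)NC(=O)c2ccc(OCc3ccccc3)cc2)cc1-c1nc2ccccc2[nH]1`: 30100 nM
- compound 2, `Cc1ccc(NC(=O)NC(=O)c2ccc(OCc3cccc(C(F)(F)F)c3)cc2)cc1-c1nc2ccccc2[nH]1`: 9640 nM

Among these two numbers compound 2 stands lowest; its nearest neighbour is compound 1, and the difference between them is a 3.1-fold lower number from compound 1 to compound 2 (0.49 log units; beyond the scatter), the only step measured here. It is also the only one that bears on the next change, since it shows what the trifluoromethyl on the benzyl ring is worth. Compound 3, `Cc1ccc(NC(=O)NC(=O)c2ccc(OCc3ccccc3F)cc2)cc1-c1nc2ccccc2[nH]1`, differs from compound 2 by 2-fluorophenyl in place of 3-(trifluoromethyl)phenyl on a saturated chain carbon bound to an oxygen on an aromatic ring. The trifluoromethyl that gave compound 2 its gain over compound 1 is thus taken away again, and a single fluorine on a different position enters instead. The expected step is therefore upward, toward the number of compound 1, though not necessarily all the way, estimated as a 2.1-fold higher number from compound 2 to compound 3 (0.32 log units; beyond the scatter). For compound 3 the expected value in this assay is 20000 nM, with a likely range from 7000 nM to 60000 nM.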

Compound 3, half-maximal inhibitory concentration: 4110 nM
Beside the measured number, compound 3's estimate is 4.9-fold (0.69 log units) above it; measured number below the stated range.
By their numbers in this assay, from the lowest: compound 3; then compound 2; then compound 1.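

In this assay, a substituent on the benzyl ring does not need the bulk of a trifluoromethyl to lower the number: a single fluoro in place of hydrogen gives a 7.3-fold lower number from compound 1 to compound 3 (0.86 log units; beyond the scatter). Swapping 3-(trifluoromethyl)phenyl, with 10 heavy atoms, for 2-fluorophenyl, with 7, gives a 2.3-fold lower number from compound 2 to compound 3 (0.37 log units; beyond the scatter), so the lower number here goes with the group of fewer heavy atoms, and both substituted compounds stand below the unsubstituted one with no compound going against that. Nothing available explains why this swap lowers the number.

Because both the group and its place on the ring change in this swap, the two contributions cannot be told apart. As far as these compounds go, whether a chlorine, a methoxy group or a nitrile on this ring would lower the number further also remains open.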